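Replacing the ethoxy group of compound 1

A few compounds are considered here, and "the series" means these few. Any claim that something is new, unique, unknown or untested is made for them only; others in the source may bear on it.

- Compound 1 `CCCCCC[C@@]1(C)SC(=O)C=C1OCC(=O)OCC`: 39.6 ug/mL
- Compound 2 `CCCCCCCC[C@@]1(C)SC(=O)C=C1OCC(=O)OCC`: 35.3 ug/mL

These two numbers come from a functional assay on MCF7 cells (Homo sapiens) for inhibition, read by radiometric assay and XTT assay (a higher number here means a weaker inhibitor, a lower number a stronger inhibitor), and they cannot be told apart. Within the data shown here, the step of a 1.1-fold lower number from compound 1 to compound 2 (0.05 log units; within the scatter) stays within the usual scatter, so compound 1 stands level with the only other compound measured so far.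

Compound 3 `CCCCCC[C@@]1(C)SC(=O)C=C1OCC(=O)NCC(=O)OC` keeps the core of compound 1 and alters one end of the molecule: ((methoxycarbonyl)methyl)amino in place of ethoxy on a carbonyl carbon. In short, ((methoxycarbonyl)methyl)amino takes the place of ethoxy on a carbonyl carbon.

Among the measured compounds shown here, the one measured step offers little guidance here. For the measured compounds named here, it concerns a saturated chain carbon rather than the carbonyl carbon, so no measurement yet shows what a swap at this carbonyl does. With nothing pointing either way, no step beyond the scatter is expected in this assay, although the uncertainty is wide. The expectation therefore starts from compound 1 at 39.6 ug/mL. The expected change is a 1.0-fold higher number from compound 1 to compound 3 (0.00 log units; within the scatter). For compound 3 the estimated value is 40 ug/mL, with an expected range from 15 ug/mL to 100 ug/mL.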

Compound 3, half-maximal inhibitory concentration: 40.5 ug/mL
Compound 3: middle estimate off by 1.0-fold (0.01 log units), on the low side; the measured number falls inside the stated range.
By their numbers in this assay, from the lowest: compounds 2, 1 and 3 (each within the scatter of the next).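

In this assay, ((methoxycarbonyl)methyl)amino in place of ethoxy on a carbonyl carbon gives a 1.0-fold higher number from compound 1 to compound 3 (0.01 log units; within the scatter), so compound 1 and compound 3 cannot be told apart. Among these compounds, this is the first measured change at this carbonyl carbon, and it is not a small alteration on paper: the entering group has 6 heavy atoms where ethoxy has 3, and it brings 1 hydrogen-bond donor where ethoxy has 0, yet the step stays within the usual scatter. No measurement available here bears on why this change leaves the number where it is.

A single swap at this carbonyl carbon cannot show how far that result extends: a carboxylic acid in place of the methoxycarbonyl end of the new group, or a phenyl ring on the amide nitrogen, could still separate from compound 1. As far as these compounds go, it also remains open whether the same swap would read the same way on the longer chain of compound 2.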